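Phenyl substitution in the series: compound 3 to compound 4

The source may hold more compounds than are shown below. What is called first, only, known or untested is meant among the compounds shown, and "the series" means these compounds.

Values in an assay on HepG2 cells for agonist activity at nuclear receptor subfamily 1 group I member 3 (Homo sapiens), read by a luciferase reporter, with a stated time of 23 h; on this read-out lower numbers stand for an effect already at smaller amounts and higher numbers for an effect only at larger amounts of compound:
compound 1 `COc1ccc(CO/N=C/c2c(-c3ccc4ccccc4c3)nc3occn23)cc1` gives 4400 nM
compound 2 `CC(C)(C)c1ccc(CO/N=C/c2c(-c3ccc4ccccc4c3)nc3occn23)cc1` gives 7900 nM
compound 3 `C(=N/OCc1ccccc1)\c1c(-c2ccc3ccccc3c2)nc2occn12` gives 840 nM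

Compound 3 stands lowest of the three numbers: a 5.2-fold lower number from compound 1 to compound 3 (0.72 log units; beyond the scatter) and a 9.4-fold lower number from compound 2 to compound 3 (0.97 log units; beyond the scatter) both lie beyond the scatter, while the gap between compound 1 and compound 2, a 1.8-fold higher number from compound 1 to compound 2 (0.25 log units; within the scatter), does not. Compound 4 `FC(F)(F)c1ccc(CO/N=C/c2c(-c3ccc4ccccc4c3)nc3occn23)cc1` differs from compound 3 by trifluoromethyl in place of hydrogen on an aromatic carbon. The two steps that bear on it are the ones removing a group from the same place, a 5.2-fold lower number from compound 1 to compound 3 (0.72 log units; beyond the scatter) and a 9.4-fold lower number from compound 2 to compound 3 (0.97 log units; beyond the scatter); both lower the number, so a group entering there is expected to raise it by a modest amount. For compound 4 the expected step is a 5.4-fold higher number from compound 3 to compound 4 (0.73 log units; beyond the scatter), so compound 4 is estimated at 4500 nM in this assay, within a range of 1500 nM to 13000 nM.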

Compound 4, half-maximal effective concentration: 470 nM
Estimate against measurement, compound 4: 9.6-fold (0.98 log units) above, outside the stated range (below it).
By their numbers in this assay, from the lowest: compounds 4 and 3 (each within the scatter of the next); then compounds 1 and 2 (each within the scatter of the next).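

In this assay a group at this place on the phenyl does not by itself raise the number: phenyl to 4-(trifluoromethyl)phenyl gives a 1.8-fold lower number from compound 3 to compound 4 (0.25 log units; within the scatter) and leaves compound 4 level with compound 3 within the scatter. The outcome depends on which group enters, as shown by a 17-fold lower number from compound 2 to compound 4 (1.23 log units; beyond the scatter) and by a 9.4-fold lower number from compound 1 to compound 4 (0.97 log units; beyond the scatter) in the same series. Nothing measured here accounts for this split among the groups.

On these data alone, whether chlorine, a nitrile, an amine or a carboxylic acid at this place would track with trifluoromethyl or with methoxy and tert-butyl remains open.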